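The source may report more compounds than this note shows. Statements on the series, on what has been measured and on what is new or still open speak of the compounds shown alone.

Working notes, compound 2 to compound 3.

Within the data shown here, compound 2 `C1=C(c2ccccn2)CCN(CCCCc2ccncc2)C1` stands at the higher of the two numbers so far in an assay (brain, Cavia porcellus) for binding affinity to Sigma non-opioid intracellular receptor 1 (Homo sapiens), read by radioligand binding; on this read-out higher numbers stand for weaker inhibition and lower numbers for stronger inhibition: compound 2 gives 44.5 nM, while compound 1 `Clc1ccc(C2=CCN(CCCCc3ccncc3)CC2)cc1` gives 1.04 nM. Among the measured compounds shown here, the single step between them, a 43-fold higher number from compound 1 to compound 2 (1.63 log units; beyond the scatter), shows that an exchange of the group on the double-bonded ring carbon of the shared core can move the number far beyond the scatter.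

Compound 3 `C1=C(c2cccs2)CCN(CCCCc2ccncc2)C1` is the next member, and its change from compound 2 is thiophen-2-yl in place of pyridin-2-yl on a double-bonded ring carbon. For the measured compounds named here, no measured step covers this particular exchange; the one step on record concerns a different group at the same position, so it bears on compound 3 only by showing that the position is sensitive. On that basis a step beyond the scatter is expected in this assay for compound 3, and because compound 2 already sits at the high end of the two numbers with 44.5 nM, the more likely direction is downward. Compound 3 is therefore estimated at 6 nM, with a range from 1.2 nM to 35 nM. The step this estimate implies, a 7.4-fold lower number from compound 2 to compound 3 (0.87 log units; beyond the scatter), is expected but carries wide uncertainty, and the measurement will decide.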

Compound 3, inhibition constant: 2.13 nM
Estimate against measurement, compound 3: 2.8-fold (0.45 log units) above; measured number inside the range.
By their numbers in this assay, from the lowest: compound 1; then compound 3; then compound 2.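

The step of a 21-fold lower number from compound 2 to compound 3 (1.32 log units; beyond the scatter) in this assay shows that this position can move the number strongly downward as well as upward, and that the high number of compound 2 is not shared by every group here that carries a ring hetero atom. Thiophen-2-yl and pyridin-2-yl each count one hetero atom and one hydrogen-bond acceptor, so these counts do not sort the two compounds, while the step of a 2.0-fold higher number from compound 1 to compound 3 (0.31 log units; beyond the scatter) is modest though beyond the scatter and leaves the five-membered ring of compound 3 close to the six-membered ring of compound 1, so ring size alone does not sort the three compounds either. Nothing on record explains why these groups differ as they do.

With one example of each ring, the compounds shown leave open whether the high number of compound 2 follows the ring nitrogen itself or its place in the ring, a question that pyridin-3-yl, pyridin-4-yl and unsubstituted phenyl on the same carbon would bear on. Also open, as far as these compounds go, is how this position responds to thiophen-3-yl, or to a ring carrying an amine or a carboxylic acid.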